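Changing the aryl group on the carbonyl of compound 2

This account rests on a few compounds, and the source may have more. Where it says the series, first, only, none or still open, it means among the compounds named here.

Compound 1 (`COc1ccc(C(=O)/C=C\Nc2ccc(-c3nc4cc(OC)c(OC)c(OC)c4s3)cc2)cc1O`) gives 14100 nM while compound 2 (`COc1ccc(C(=O)/C=C\Nc2ccc(-c3nc4cc(OC)c(OC)c(OC)c4s3)cc2)cc1F`) gives 7300 nM in a functional assay on HeLa cells (Homo sapiens) for antiproliferative activity, read by sulforhodamine B assay, with a stated time of 48 h (a lower number here means a stronger inhibitor, a higher number a weaker inhibitor), for now, and these two numbers lie within the scatter of each other. Compound 3 (`COc1cc(C(=O)/C=C\Nc2ccc(-c3nc4cc(OC)c(OC)c(OC)c4s3)cc2)cc(OC)c1OC`) carries 3,4,5-trimethoxyphenyl in place of 3-fluoro-4-methoxyphenyl on a carbonyl carbon. For the measured compounds named here, the only measured guide is a 1.9-fold lower number from compound 1 to compound 2 (0.29 log units; within the scatter) for fluoro in place of hydroxy on an aromatic carbon, which is a different and smaller change. No clear shift is therefore expected, and the estimated change is a 1.2-fold lower number from compound 2 to compound 3 (0.09 log units; within the scatter) in this assay overall. Compound 3 is expected at 6000 nM (estimated range 1800 nM to 20000 nM).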

Compound 3, half-maximal inhibitory concentration: 5300 nM
Beside the measured number, compound 3's estimate is 1.1-fold (0.05 log units) above it, and the stated range covers the measured number.
By their numbers in this assay, from the lowest: compounds 3, 2 and 1 (each within the scatter of the next, the first and the last beyond it).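

In this assay the step to 3,4,5-trimethoxyphenyl on this carbonyl carbon gives a 1.4-fold lower number from compound 2 to compound 3 (0.14 log units; within the scatter) so the bulkier group, with more heavy atoms, is accommodated about as well as 3-fluoro-4-methoxyphenyl. Set against 3-hydroxy-4-methoxyphenyl, the same group gives a 2.7-fold lower number from compound 1 to compound 3 (0.42 log units; beyond the scatter) and this is the first step here to clear the scatter, though only modestly. Nothing measured here explains this difference.

Still open, going by these compounds, is whether an aryl group carrying an amine or a carboxylic acid would shift the number at this carbonyl carbon. A plain phenyl group is equally untested among the compounds shown.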